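The source may report more compounds than this note shows. Statements on the series, on what has been measured and on what is new or still open speak of the compounds shown alone.

Measured compounds:
compound 1, `COc1ccc(O)c(C(=O)NCC(C)(C)CC2=C(O)C(=O)c3ccccc3C2=O)c1`, 39600 nM;
compound 2, `COc1ccc(OC)c(C(=O)NCC(C)(C)CC2=C(O)C(=O)c3ccccc3C2=O)c1`, 99400 nM;
compound 3, `COc1cc(C(=O)NCC(C)(C)CC2=C(O)C(=O)c3ccccc3C2=O)c(OC)c2ccccc12`, reported as "not active" (no number reported).

The three compounds were tested in a functional assay on MCF7 cells (Homo sapiens) for cytotoxicity, read by resazurin assay, with a stated time of 3 days; a lower number here means a stronger inhibitor, a higher number a weaker inhibitor. Compound 1 gives 39600 nM there, and compound 2 gives 99400 nM. The two differ in one place, (methyl in place of hydrogen on an oxygen on an aromatic ring), and that change made a step of a 2.5-fold higher number from compound 1 to compound 2 (0.40 log units; beyond the scatter). Compound 3 is described only as not active in this assay, with no number behind it. How the core of compound 3 differs from the core of compound 1 is not broken down here.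

Compound 4, `COC1=C(CC(C)(C)CNC(=O)c2cc(OC)c3ccccc3c2OC)C(=O)c2ccccc2C1=O`, has not yet been measured. It differs from compound 3 by methyl in place of hydrogen on an oxygen on an unsaturated carbon. Among the measured compounds shown here, this is the same kind of change as the one from compound 1 to compound 2, but the place is not the same: in the earlier pair the oxygen sits on an aromatic ring whose other neighbours are aromatic carbon, while here it sits on an unsaturated carbon whose other neighbours are a double-bonded ring carbon.

For the measured compounds named here, the only measured step of this kind was modest and went toward a weaker inhibitor, from compound 1 to compound 2 by a 2.5-fold higher number from compound 1 to compound 2 (0.40 log units; beyond the scatter). Compound 3 already has no reported number in this assay. With the same kind of change on a compound that starts from no activity, compound 4 is expected to come out weak as well, with a large chance that this assay again reports no number; the estimate for compound 4 is 150000 nM, in a range from 50000 nM to 500000 nM.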

Compound 4, half-maximal inhibitory concentration: "not active" (no number reported)
For compound 4 the study gives words and no number, and the estimate cannot be compared.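

Compound 3 and compound 4 are both described only as not active in this assay with no number behind either, so no step can be read between them. Nothing further on hand bears on this result. The compounds shown leave open whether hydroxy to methoxy at this place changes activity at all, and whether it compares with the step of a 2.5-fold higher number from compound 1 to compound 2 (0.40 log units; beyond the scatter) seen on the other core.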